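Adding 4-methylpiperazin-1-yl to the propyl chain of compound 2

The source may hold more compounds than are shown below. What is called first, only, known or untested is meant among the compounds shown, and "the series" means these compounds.

In a functional assay on Raji cells (Homo sapiens) for antiproliferative activity, read by MTT assay, with a stated time of 48 h (a higher number here means a weaker inhibitor, a lower number a stronger inhibitor), compound 1 `N#Cc1nc2c(-c3nc4ccccc4[nH]3)c(N)n(CCN3CCCC3)c2nc1C#N` gives > 50000 nM as a limit of the assay, not a number. Compound 2 `CCCn1c(N)c(-c2nc3ccccc3[nH]2)c2nc(C#N)c(C#N)nc21` gives > 50000 nM as a limit too. For the measured compounds named here, that leaves a step that the two limits leave unreadable from compound 1 to compound 2 as the only measured step, and the limit of > 50000 nM in this assay, at which 2 of the 2 values shown sit, as the whole of the evidence. Compound 3 `CN1CCN(CCCn2c(N)c(-c3nc4ccccc4[nH]3)c3nc(C#N)c(C#N)nc32)CC1` differs from compound 2 by 4-methylpiperazin-1-yl in place of hydrogen on a saturated chain carbon, three bonds along the chain from an aromatic nitrogen and so turns propyl into 3-(4-methylpiperazin-1-yl)propyl. Compound 1 has pyrrolidin-1-yl on its chain and still gives > 50000 nM as a limit, so little gain is expected. The expected change is an at least 1.2-fold lower number from compound 2 to compound 3 (0.09 log units; that floor lies within the scatter) in this estimate. For compound 3 the estimated value is 40000 nM with 10000 nM to 80000 nM as the expected range.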

Compound 3, half-maximal inhibitory concentration: 2620 nM
Beside the measured number, compound 3's estimate is 15-fold (1.18 log units) above it; measured number outside the range, below it.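

On a saturated chain carbon, three bonds along the chain from an aromatic nitrogen, adding 4-methylpiperazin-1-yl gives an at least 19-fold lower number from compound 2 to compound 3 (1.28 log units; beyond the scatter). The group on the chain therefore matters, since an at least 19-fold lower number from compound 1 to compound 3 (1.28 log units; beyond the scatter) shows that a chain bearing pyrrolidin-1-yl does not do the same job. Both steps are only floors, because each starts from a limit and not a number: the limit of > 50000 nM in this assay, at which 2 of the 3 values shown sit.

The compounds shown leave open whether the gain needs the whole 4-methylpiperazin-1-yl group or the propyl length. Piperazin-1-yl, morpholin-4-yl or a 2-(4-methylpiperazin-1-yl)ethyl chain would help separate these.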